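The source may report more compounds than this note shows. Statements on the series, on what has been measured and on what is new or still open speak of the compounds shown alone.

Measured so far:
- compound 1 `COc1ccc(-c2cn3cc(C4=CCN(C(=O)c5ccccc5C(F)(F)F)CC4)ccc3n2)cc1OC`: 8110 nM
- compound 2 `COc1ccc(-c2cn3cc(C4=CCN(C(=O)C5CCCCC5)CC4)ccc3n2)cc1OC`: 10900 nM

In a functional assay on B16-F10 cells (Mus musculus) for antiproliferative activity, read by MTT assay, with a stated time of 48 h (a higher number here means a weaker inhibitor, a lower number a stronger inhibitor), compound 2 gives the higher of the two numbers; compound 1 is nearest, and the step of a 1.3-fold higher number from compound 1 to compound 2 (0.13 log units; within the scatter) lies within the scatter, so the two cannot be ordered.

Compound 3 `COc1ccc(-c2cn3cc(C4=CCN(C(=O)c5ccc(Cl)cc5)CC4)ccc3n2)cc1OC` differs from compound 2 by 4-chlorophenyl in place of cyclohexyl on a carbonyl carbon. Among the measured compounds shown here, the only measured step that bears on this change is a 1.3-fold higher number from compound 1 to compound 2 (0.13 log units; within the scatter), an exchange of the ring on the same carbonyl carbon, and it moved the number little. With compound 3 a six-membered aromatic ring returns at that position, as in compound 1, so no step beyond the scatter is expected in this assay, at most a drift toward the lower number of compound 1. For compound 3 the value in this assay is estimated at 8500 nM, with a range of 4000 nM to 18000 nM. The step this estimate implies is a 1.3-fold lower number from compound 2 to compound 3 (0.11 log units; within the scatter).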

Compound 3, half-maximal inhibitory concentration: 15300 nM
Beside the measured number, compound 3's estimate is 1.8-fold (0.26 log units) below it; the measured number falls inside the stated range.
By their numbers in this assay, from the lowest: compounds 1, 2 and 3 (each within the scatter of the next).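

In this assay, the ring on the carbonyl carbon now spans 2-(trifluoromethyl)phenyl, cyclohexyl and 4-chlorophenyl, and no two of the three compounds can be ordered: a 1.4-fold higher number from compound 2 to compound 3 (0.15 log units; within the scatter) and a 1.9-fold higher number from compound 1 to compound 3 (0.28 log units; within the scatter) both lie within the scatter. Among the compounds shown here, the second step is the first comparison of two substituted aromatic rings at this place, and it does not separate them, while the first shows that the return to an aromatic ring does not separate compound 3 from the cyclohexyl compound either. No measurement at hand bears on these numbers.

From the compounds shown here alone, all three compounds carry a six-membered ring on the carbonyl carbon, so it remains open whether an amine, a carboxylic acid or a longer alkyl chain there would give a step beyond the scatter. Also open, going by these compounds, is whether a change elsewhere on the shared core would do so.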